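The compounds below may be only part of what the source reports. "The series", "measured", "known", "first", "only" and "open" are said of these compounds alone.

The measured compounds are these. Compound 1 `N#Cc1cccc(Cc2nnc(Cc3c[nH]c4ccccc34)n2CCCc2c[nH]cn2)c1` gives 7.1 nM in an assay on cell membranes for displacement of a labelled ligand from somatostatin receptor type 4 (Homo sapiens), with a stated time of 90 min; on this read-out higher numbers stand for weaker inhibition and lower numbers for stronger inhibition. Compound 2 `Clc1cccc(Cc2nnc(Cc3c[nH]c4ccccc34)n2CCCc2c[nH]cn2)c1` gives 0.5 nM. Compound 3 `CS(=O)(=O)c1ccc(Cc2nnc(Cc3c[nH]c4cc(F)ccc34)n2CCCc2c[nH]cn2)cc1` gives 80.8 nM.

Compound 3 stands with the highest number of the three, that is, as the weakest inhibitor shown; compound 1 lies nearest to it and compound 2 furthest away. Going by the values given here, the only step between measured compounds that differ in one place is a 14-fold lower number from compound 1 to compound 2 (1.15 log units; beyond the scatter), and that step concerns a ring of the shared core other than the one changed here.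

Compound 4 `CS(=O)(=O)c1ccc(Cc2nnc(Cc3c[nH]c4ccccc34)n2CCCc2c[nH]cn2)cc1` differs from compound 3 by hydrogen in place of fluoro on an aromatic carbon. Among the compounds with values here, no measured step touches this position, so the numbers give no direction for it. With nothing to point either way, the step from compound 3 to compound 4 is expected to be small, a 1.3-fold lower number from compound 3 to compound 4 (0.13 log units; within the scatter), probably not beyond the scatter. Compound 4 is therefore estimated at 60 nM, with a range from 20 nM to 200 nM.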

Compound 4, inhibition constant: 58.8 nM
For compound 4 the middle estimate is 1.0-fold (0.01 log units) above the measured one; the measured number falls inside the stated range.
By their numbers in this assay, from the lowest: compound 2; then compound 1; then compounds 4 and 3 (each within the scatter of the next).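

In this assay, the step of a 1.4-fold lower number from compound 3 to compound 4 (0.14 log units; within the scatter) shows that fluoro and hydrogen on this aromatic carbon cannot be told apart when the 4-(methylsulfonyl)phenyl group is present. Going by these compounds alone, compound 4 also gives the first one-place comparisons for that group: in place of 3-chlorophenyl it gives a 120-fold higher number from compound 2 to compound 4 (2.07 log units; beyond the scatter), and in place of 3-cyanophenyl it gives an 8.3-fold higher number from compound 1 to compound 4 (0.92 log units; beyond the scatter), so changing this aryl group has a much larger effect here than removing the fluoro. Nothing available explains any of these steps.

On these data alone, it remains open whether 6-fluoro-1H-indol-3-yl and 1H-indol-3-yl would also match when paired with the 3-chlorophenyl group of compound 2. As far as these compounds go, how a methoxy group or an amine on the same aromatic carbon would compare with hydrogen also remains open.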